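Varying the group on the aromatic nitrogen in an agonist series

The compounds below may be only part of what the source reports. "The series", "measured", "known", "first", "only" and "open" are said of these compounds alone.

Compound 2 `N#Cc1c(-c2ccc3c(ccn3[C@H]3CC[C@H](O)CC3)c2)ccn2c(CC(F)(F)F)cnc12` carries a 4-hydroxycyclohexyl group on an aromatic nitrogen of its core. In a functional assay on CHO cells for agonist activity at metabotropic glutamate receptor 2 (Homo sapiens) (on this read-out lower numbers stand for smaller maximal responses and higher numbers for larger maximal responses), compound 2 gives 237%, the second highest of the three numbers at hand: compound 1 `N#Cc1c(-c2ccc3c(ccn3CC3CC3)c2)ccn2c(CC(F)(F)F)cnc12` gives 230% and compound 3 `O[C@H]1CC[C@H](n2ccc3cc(-c4ccn5c(CC(F)(F)F)cnc5c4Cl)ccc32)CC1` gives 244%. The step of a number 7 percentage points higher from compound 1 to compound 2 (within the scatter) and the step of a number 7 percentage points higher from compound 2 to compound 3 (within the scatter) both lie within the scatter, so the three compounds cannot be ranked against one another in this assay. Compound 4 `N#Cc1c(-c2ccc3c(ccn3C3CCOCC3)c2)ccn2c(CC(F)(F)F)cnc12` has not been measured; it differs from compound 2 as follows: oxan-4-yl in place of 4-hydroxycyclohexyl on an aromatic nitrogen. The comparison that bears most directly on this change is the step of a number 7 percentage points higher from compound 1 to compound 2 (within the scatter), which also exchanged the group on an aromatic nitrogen and stayed within the scatter; the step of a number 7 percentage points higher from compound 2 to compound 3 (within the scatter), on an aromatic carbon, was equally small. No structural change in this set has moved the maximal response beyond the scatter. On this basis compound 4 is expected to give about 235% in this assay, with a likely range from 200% to 270%. The step of a number 2 percentage points lower from compound 2 to compound 4 (within the scatter) is accordingly estimated to remain within the scatter.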

Compound 4, largest response reached (Emax), in percent of the reference or control that the assay uses: 442%
Beside the measured number, compound 4's estimate is 207 percentage points below it; measured number above the stated range.
By their numbers in this assay, from the lowest: compounds 1, 2 and 3 (each within the scatter of the next, the first and the last beyond it); then compound 4.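

In this assay the group on the aromatic nitrogen proved able to move the maximal response far beyond the scatter: the step of a number 205 percentage points higher from compound 2 to compound 4 (beyond the scatter) and the step of a number 212 percentage points higher from compound 1 to compound 4 (beyond the scatter) are both large, whereas the earlier exchange at this position stayed within it. The response at this position therefore does not follow a single level, since cyclopropylmethyl and 4-hydroxycyclohexyl cannot be told apart while oxan-4-yl stands clear of both. The data offer no explanation for this jump.

Going by these compounds, whether the rise is specific to oxan-4-yl remains open, and a plain cyclohexyl or a piperidin-4-yl ring, with an amine nitrogen in place of the ring oxygen, would bear on that. Also open, on these data alone, is whether oxan-4-yl gives the same rise with chloro in place of cyano on the aromatic carbon.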